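The compounds below may be only part of what the source reports. "The series", "measured", "known", "first", "only" and "open" are said of these compounds alone.

Measured in a functional assay on BV-2 cells (Mus musculus) for inhibition, read by Griess assay, with a stated time of 24 h; a lower number here means a stronger inhibitor, a higher number a weaker inhibitor:
- compound 1 `C=C(C)[C@@H]1CC[C@](C)(O)[C@H]1/C=C/C(C)=C/[C@@H]1C[C@@]2([C@H](OC)O1)[C@H](CCCO)/C(=C(\C)C=O)CC[C@]2(C)O`: > 10000 nM
- compound 2 `C=C(C)[C@H]1CC[C@@](C)(O)[C@@H]1/C=C/C(C)=C/[C@@H]1C[C@@]2([C@H](OC)O1)[C@H](CCCO)/C(=C(\C)C=O)CC[C@]2(C)O`: > 10000 nM

For compound 2 the reading > 10000 nM is a limit and not a number. Compound 1 also gives only a limit, so no measured number is yet available in this assay.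

Compound 3 `C=C(C)[C@H]1CC[C@@](C)(O)[C@@H]1/C=C/C(C)=C/[C@@H]1C[C@@]2([C@H](OCC)O1)[C@H](CCCO)/C(=C(\C)C=O)CC[C@]2(C)O` keeps the frame of compound 2 and makes one change: methyl in place of hydrogen on a saturated chain carbon bound to an oxygen on a saturated carbon. In other words, methoxy becomes ethoxy.

For the measured compounds named here, only one measured step exists, a step that the two limits leave unreadable from compound 1 to compound 2. It offers little guidance here, as it rests on the fact that compounds 1 and 2 differ only in the configuration as drawn and its size cannot be read. Going by the values given here, no measured step shows what a change from methoxy to ethoxy does.

The safest expectation is therefore no readable step in either direction, because the limit of > 10000 nM in this assay, at which 2 of the 2 values shown sit, is all that the data show. Compound 3 will most likely also stop at a limit. The estimated step is a step that the limit leaves unreadable from compound 2 to compound 3.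

For compound 3 the expected value is 12000 nM, with an estimated range from 5000 nM to 30000 nM.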

Compound 3, half-maximal inhibitory concentration: > 10000 nM
Compound 3: no number, only a limit (the forecaster's own chance of this, stated with the estimate: 75%); the middle value does not contradict the limit.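

In this assay compound 3 gives > 10000 nM, which is a limit and not a number. Compound 2 also gives only a limit, so the step from methoxy to ethoxy cannot be read. The compounds shown leave open how strongly any of them inhibits in this assay, and whether this change affects inhibition at all.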